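The source may hold more compounds than are shown below. What is called first, only, known or untested is meant among the compounds shown, and "the series" means these compounds.

Measured compounds and their values in an ADME assay on 184B5 cells (Homo sapiens) for cytotoxicity, read by sulforhodamine B assay, with a stated time of 48 h; on this read-out higher numbers stand for weaker inhibition of growth and lower numbers for stronger inhibition of growth:

compound 1 `Cc1ccc2nc(/N=C3\C(=O)N(CN(c4ccccc4)c4ccccc4)c4cccc(Br)c43)sc2c1`: 70300 nM
compound 2 `CN(C)CN1C(=O)C(=O)c2c(Br)cccc21`: 77900 nM
compound 3 `Cc1ccc2nc(/N=C3\C(=O)N(CN(c4ccccc4)c4ccccc4)c4ccccc43)sc2c1`: 27200 nM

Compound 1 and compound 3 share one core and differ in a single place: hydrogen in place of bromo on an aromatic carbon. In this assay this change gives a 2.6-fold lower number from compound 1 to compound 3 (0.41 log units; beyond the scatter), a shift that lies beyond the usual scatter of repeated measurements, though still modest in size.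

Compound 2 is built on a different core; the difference between the two cores is not broken down here. In this assay compound 2 gives 77900 nM, which sits within the scatter of the value of compound 1, while the gap to compound 3 lies beyond the scatter.

Compound 4 `CN(C)CN1C(=O)C(=O)c2ccccc21` has not yet been measured. It is related to compound 2 in the same way that compound 3 is related to compound 1: hydrogen in place of bromo on an aromatic carbon. The two descriptions of the place agree word for word, so this is the same change made on the second core. Going by the values given here, the only guide to its effect is the single earlier instance, compound 1 to compound 3, which gave a 2.6-fold lower number from compound 1 to compound 3 (0.41 log units; beyond the scatter). On that basis compound 4 is expected to follow the same direction: the estimated step is a 2.4-fold lower number from compound 2 to compound 4 (0.37 log units; beyond the scatter), and the estimate for compound 4 in this assay is 33000 nM, with a range of 14000 nM to 80000 nM. Among the compounds with values here, with only one prior example, on a different core, the range is kept wide.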

Compound 4, concentration for 50% growth inhibition: 73700 nM
The estimate for compound 4 lay 2.2-fold (0.35 log units) below the measured number, and the stated range covers the measured number.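

On the second core, in this assay, hydrogen in place of bromo on an aromatic carbon gives a 1.1-fold lower number from compound 2 to compound 4 (0.02 log units; within the scatter), so no step can be read on this core. Set beside the earlier step on the first core, the result does not separate the two cores: the same change on two cores in this assay, a 2.6-fold lower number (0.41 log units; beyond the scatter) from compound 1 to compound 3 and a 1.1-fold lower number (0.02 log units; within the scatter) from compound 2 to compound 4, 2.4-fold (0.39 log units) apart, within the scatter of two such steps. Going by these compounds alone, this shows no measured dependence of the change on the core, but it does not show that the change carries over, since only one of the two steps lies beyond the scatter and the comparison rests on just two pairs, so a small real difference between the cores, or a shared small effect, remains possible.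

The compounds shown compare only bromo with hydrogen at one place on the six-membered aromatic ring, which leaves open how other groups there, such as chloro, methoxy, an amine or a carboxylic acid, would read on either core. Also open, from the compounds shown here alone, is whether the step on the first core would hold up in further pairs, or on cores that carry a longer chain in place of the groups seen here.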